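The compounds below may be only part of what the source reports. "The series", "measured", "known", "first", "only" and "open" are said of these compounds alone.

Series notes. In an assay on isolated protein for inhibition of Amine oxidase [flavin-containing] A (Homo sapiens), read by spectrophotometry (a lower number here means a stronger inhibitor, a higher number a weaker inhibitor), compound 1 `Clc1ccc(/C=N/Nc2nc3ccccc3nc2Cc2ccccc2)cc1` gives 76 nM, compound 2 `C/C(=N\Nc1nc2ccccc2nc1Cc1ccccc1)c1ccccc1` gives 79 nM and compound 3 `C/C(=N\Nc1nc2ccccc2nc1Cc1ccccc1)c1ccccn1` gives 91 nM. Compound 3 stands alongside the other two: the step of a 1.2-fold higher number from compound 1 to compound 3 (0.08 log units; within the scatter) and the step of a 1.2-fold higher number from compound 2 to compound 3 (0.06 log units; within the scatter) are both within the scatter, as is a 1.0-fold higher number from compound 1 to compound 2 (0.02 log units; within the scatter). Compound 4 `Brc1cccc(/C=N/Nc2nc3ccccc3nc2Cc2ccccc2)c1` differs from compound 3 by a group of 9 heavy atoms (7 carbon, 1 nitrogen, 1 bromine; one six-membered aromatic ring of carbon only) in place of a group of 9 heavy atoms (7 carbon, 2 nitrogen; one six-membered aromatic ring with 1 hetero atom), on a nitrogen on an aromatic ring. This exchange runs back towards the kind of group carried by compound 1, and because the comparable step a 1.2-fold higher number from compound 1 to compound 3 (0.08 log units; within the scatter) was within the scatter, no step beyond the scatter is expected in this assay in either direction. The expected step of a 1.2-fold lower number from compound 3 to compound 4 (0.08 log units; within the scatter) is small. Compound 4 is accordingly estimated at 75 nM, with a range of 35 nM to 160 nM.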

Compound 4, half-maximal inhibitory concentration: 9.8 nM
Estimate against measurement, compound 4: 7.7-fold (0.88 log units) above; measured number below the stated range.
By their numbers in this assay, from the lowest: compound 4; then compounds 1, 2 and 3 (each within the scatter of the next).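

Compounds 1, 2 and 3 suggested that this position tolerates change without effect, but in this assay it proves responsive (a 9.3-fold lower number from compound 3 to compound 4 (0.97 log units; beyond the scatter)) and (an 8.1-fold lower number from compound 2 to compound 4 (0.91 log units; beyond the scatter)). The step from the closest neighbour is of similar size (a 7.8-fold lower number from compound 1 to compound 4 (0.89 log units; beyond the scatter)), and there only the aryl group differs, so the gain follows the 3-bromophenyl group and not just the loss of the methyl on the carbon with a double bond to nitrogen. No available measurement explains the gain. Still open, going by these compounds, is whether bromine or its ring place carries the gain. A 4-bromophenyl or 3-chlorophenyl group would separate the two.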